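The compounds below may be only part of what the source reports. "The series", "measured", "known", "first", "only" and "open" are said of these compounds alone.

For the measured compounds named here, compound 1 `CC(=O)c1ccc(OC(=O)c2ccc(-c3ccccc3)cc2)cc1` and compound 2 `COc1ccc(C(=O)/C=C/c2cc3cc(C)ccc3nc2Cl)cc1` are the two measured members. In an assay on membranes from cerebellum for displacement of a labelled ligand from metabotropic glutamate receptor 1 (Rattus norvegicus), read by scintillation counting, with a stated time of 16 h (a lower number here means a stronger inhibitor, a higher number a weaker inhibitor), compound 1 reaches only a limit of > 40000 nM. Compound 2 likewise gives only a limit of > 40000 nM in this assay, so no number fixes where it stands. Both results sit at the limit of > 40000 nM in this assay, at which 2 of the 2 values shown sit. Compound 3 `Cc1ccc2nc(Cl)c(/C=C/C(=O)c3cccs3)cc2c1` is not yet measured; it differs from compound 2 by thiophen-2-yl in place of 4-methoxyphenyl on a carbonyl carbon. Going by the values given here, no step between measured compounds is available, so no shift beyond the scatter is expected, and the expected step is a number no higher from compound 2 to compound 3 (the limit leaves the size open). Compound 3 is expected to give 40000 nM in this assay, within 15000 nM to 100000 nM, most likely again only as a limit.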

Compound 3, inhibition constant: 9930 nM
Compound 3: the middle estimate sits 4.0-fold (0.61 log units) above what was measured; the whole stated range lies above it.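

On a carbonyl carbon, thiophen-2-yl in place of 4-methoxyphenyl produces a readable shift in this assay: an at least 4.0-fold lower number from compound 2 to compound 3 (0.60 log units; beyond the scatter). This position can therefore move the number, which the two earlier compounds could not show, and compound 3 is the only one shown with a value rather than a limit. The true size of the step stays open because compound 2 rests on a limit: the limit of > 40000 nM in this assay, at which 2 of the 3 values shown sit.

On these data alone, it remains open whether the shift follows from gaining thiophen-2-yl or from losing 4-methoxyphenyl. A plain phenyl or a furan-2-yl on the same carbonyl carbon would separate the two.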